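Removing Both Chlorines From the Benzyl Ether of Compound 1

A few compounds are considered here, and "the series" means these few. Any claim that something is new, unique, unknown or untested is made for them only; others in the source may bear on it.

Compound 1 `COc1ccc(NC(=O)COC(=O)/C=C/c2cc(OC)c(OCc3ccc(Cl)c(Cl)c3)c(OC)c2)cc1`: > 200000 nM
Compound 2 `COCOc1ccc(/C=C/C(=O)N2CCN(Cc3ccc(Cl)c(Cl)c3)CC2)cc1OCOC`: 31000 nM
Compound 3 `O=C(COC(=O)/C=C/c1ccc(O)c(O)c1)NN1CCOCC1`: > 200000 nM

In a functional assay on HL-60 cells (Homo sapiens) for cytotoxicity, read by MTT assay, with a stated time of 72 h (on this read-out lower numbers stand for stronger inhibition and higher numbers for weaker inhibition), compound 1 gives > 200000 nM, which is a limit of the assay and not a number. Compound 3 also reaches only a limit, > 200000 nM. Among the compounds with values here, compound 2 is the one compound of the three with a measured number, 31000 nM. Compound 1 therefore stands at the limit of > 200000 nM in this assay, at which 2 of the 3 values shown sit, so nothing is known of its potency beyond the fact that it was not reached within the tested range.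

Compound 4 `COc1ccc(NC(=O)COC(=O)/C=C/c2cc(OC)c(OCc3ccccc3)c(OC)c2)cc1` is the compound still to be measured in this assay. It differs from compound 1 in one place: phenyl in place of 3,4-dichlorophenyl on a saturated chain carbon bound to an oxygen on an aromatic ring. Within the data shown here, no pair of measured compounds differs in a single place, so no measured step guides this change directly.

With compound 1 at a limit and the change confined to two chlorine atoms on the outer ring, the expected step of a number no higher from compound 1 to compound 4 (the limit leaves the size open) is none beyond the scatter, and a limit is the most likely outcome again. Compound 4 is thus estimated at about 200000 nM, within a range from 50000 nM to 600000 nM.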

Compound 4, half-maximal inhibitory concentration: > 200000 nM
Compound 4 gave a limit, no number; the forecaster's own chance of this, stated with the estimate: 80%; the middle value lies on the limit itself.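

In this assay compound 4 gives > 200000 nM, which is a limit of the assay and not a number. Compound 1 gives > 200000 nM, also a limit. No step can be read between compound 1 and compound 4. The compounds shown leave open whether phenyl in place of 3,4-dichlorophenyl changes potency at all.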